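The source may report more compounds than this note shows. Statements on the series, on what has been measured and on what is new or still open speak of the compounds shown alone.

Measured compounds in a physicochemical assay for solubility, in phosphate buffer, at pH 7.4; on this read-out higher numbers stand for higher solubility and lower numbers for lower solubility:
compound 1 `CCCCCCCCc1ccc(OCC(=O)COc2ccc3[nH]c(C(=O)O)cc3c2)cc1` gives 8.4 ug/mL.
compound 2 `CCCCCCCCc1ccc(OCC(=O)COc2ccc3c(c2)cc(C(=O)O)n3CCC)cc1` sits at the assay limit and gives no number, < 1 ug/mL.
compound 3 `CCCCCCCCc1ccc(OCC(=O)COc2ccc3c(c2)cc(C(=O)O)n3CCCCCC)cc1` likewise sits at the assay limit, < 1 ug/mL.

Compound 3 therefore stands at the floor of what this assay reports: the value for compound 3 is a limit, not a number, and compound 2 shares that limit, so between them only the limit is known and the step that the two limits leave unreadable from compound 2 to compound 3.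

The next compound is compound 4 `CCCCCCCCc1ccc(OCC(=O)COc2ccc3c(c2)cc(C(=O)O)n3Cc2ccccc2)cc1`. Against compound 3 the change is phenyl in place of pentyl on a saturated chain carbon bound to an aromatic nitrogen.

Among the measured compounds shown here, the steps that bear on it are those from the hydrogen-bearing nitrogen of compound 1: an at least 8.4-fold lower number from compound 1 to compound 2 (0.92 log units; beyond the scatter) and an at least 8.4-fold lower number from compound 1 to compound 3 (0.92 log units; beyond the scatter). Both carry a substituent onto the aromatic nitrogen and both fall to the limit; the step from compound 2 to compound 3, propyl added on the chain, is unreadable, as noted in the limit of < 1 ug/mL in this assay, at which 2 of the 3 values shown sit. Compound 4 keeps a substituent on that nitrogen, so the expectation is that compound 4 stays near the limit, with the step that the limit leaves unreadable from compound 3 to compound 4 not separable from the scatter. The estimate for compound 4 in this assay is 0.7 ug/mL, with a range from 0.2 ug/mL to 3 ug/mL, and a substantial chance that only the limit is reported.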

Compound 4, solubility: < 1 ug/mL
Compound 4: no number, only a limit; the forecaster's own chance of this, stated with the estimate: 65%; the middle value does not contradict the limit.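

In this assay compound 4 gives < 1 ug/mL, which is a limit and not a number. Benzyl in place of hydrogen on the aromatic nitrogen gives an at least 8.4-fold lower number from compound 1 to compound 4 (0.92 log units; beyond the scatter), so a substituent holding an aromatic ring now joins propyl and hexyl at this place in reaching the limit, and among the four compounds only compound 1, with hydrogen on that nitrogen, has a number. The steps from compound 2 and from compound 3 to compound 4 cannot be read, so neither phenyl in place of pentyl nor phenyl in place of ethyl has a size in this series, as both ends of each step stand at the same limit: the limit of < 1 ug/mL in this assay, at which 3 of the 4 values shown sit.

Still open, on these data alone, is whether any substituent on the aromatic nitrogen can keep a number in this assay, for instance a chain carrying an amine in place of benzyl. Also open, as far as these compounds go, is how compound 2, compound 3 and compound 4 rank among themselves, since the shared limit hides any difference between them.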